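Replacing the 2-methoxybenzyl group of compound 3

The source may hold more compounds than are shown below. What is called first, only, known or untested is meant among the compounds shown, and "the series" means these compounds.

In an ADME assay on L02 cells (Homo sapiens) for inhibition, read by CCK-8 assay, with a stated time of 48 h (a higher number here means a weaker inhibitor of growth, a lower number a stronger inhibitor of growth), compound 1 `CN1CCN(c2ccc(Nc3ncc(Cl)c(NCc4ccc(C(F)(F)F)cc4)n3)nc2)CC1` gives 26200 nM, compound 2 `COc1ccc(CNc2nc(Nc3ccc(N4CCN(C)CC4)cn3)ncc2Cl)cc1` gives 12900 nM and compound 3 `COc1ccccc1CNc1nc(Nc2ccc(N3CCN(C)CC3)cn2)ncc1Cl` gives 25500 nM. Compound 3 stands within the scatter of both other compounds, as a 1.0-fold lower number from compound 1 to compound 3 (0.01 log units; within the scatter) and a 2.0-fold higher number from compound 2 to compound 3 (0.30 log units; within the scatter) show. Only a 2.0-fold lower number from compound 1 to compound 2 (0.31 log units; beyond the scatter) goes beyond the scatter, and that step is modest.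

The next structure, compound 4 `Cc1cccc(Nc2nc(Nc3ccc(N4CCN(C)CC4)cn3)ncc2Cl)c1`, has 3-methylphenyl in place of 2-methoxybenzyl on a nitrogen on an aromatic ring. Among the measured compounds shown here, no measured step makes this change. All three measured compounds keep a saturated chain carbon on that nitrogen, and their steps exchange only the aromatic group carried by that carbon. Going by these compounds, these steps are therefore indirect guides, and the loss of the chain carbon remains untested in this assay.

Those exchanges moved the number little, so a large step is not expected here, although the uncertainty is wider than for a simple exchange. The expected step is a 1.3-fold lower number from compound 3 to compound 4 (0.11 log units; within the scatter), which would not go beyond the scatter, with no firm direction. Compound 4 is estimated at 20000 nM, with an expected range of 8000 nM to 50000 nM.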

Compound 4, concentration for 50% growth inhibition: 6080 nM
Estimate against measurement, compound 4: 3.3-fold (0.52 log units) above; the measured number lies below the stated range.
By their numbers in this assay, from the lowest: compound 4; then compounds 2, 3 and 1 (each within the scatter of the next, the first and the last beyond it).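

In this assay, the change from (2-methoxybenzyl)amino to (3-methylphenyl)amino gives a 4.2-fold lower number from compound 3 to compound 4 (0.62 log units; beyond the scatter), which shows that this nitrogen's substituent can move the number beyond the scatter when the saturated chain carbon is absent and the aromatic group is changed as well. The comparisons with the other two benzyl compounds point the same way, with a 2.1-fold lower number from compound 2 to compound 4 (0.33 log units; beyond the scatter) and a 4.3-fold lower number from compound 1 to compound 4 (0.63 log units; beyond the scatter), so compound 4 has the lowest number of the four and none of the three benzyl compounds goes against this. The data shown give no explanation for this difference.

The step joins two differences, the loss of the chain carbon and the exchange of the aromatic group, and the compounds shown cannot separate them. Going by these compounds, a 3-methylbenzyl group would test the methyl group with the chain carbon kept, while 2-methoxyphenyl or 4-methoxyphenyl on the same nitrogen would test the methoxy groups without it, and the effect of a longer chain such as 2-phenylethyl also remains open.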